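The source may report more compounds than this note shows. Statements on the series, on what has been measured and on what is new or still open speak of the compounds shown alone.

Three compounds have been measured in a functional assay on CHO-K1 cells for antagonist activity at transient receptor potential cation channel subfamily V member 1 (Homo sapiens), read by FLIPR; a lower number here means a stronger inhibitor, a higher number a weaker inhibitor:

compound 1 `Cc1ccc(Cl)cc1Nc1nc(C(F)(F)F)ccc1CNC(=O)C(C)c1ccc(NS(C)(=O)=O)c(F)c1`: compound 1 gives 14 nM
compound 2 `CC(C(=O)NCc1ccc(C(F)(F)F)nc1N1CC=CCC1)c1ccc(NS(C)(=O)=O)c(F)c1`: compound 2 gives 0.3 nM
compound 3 `CC(C(=O)NCc1ccc(C(F)(F)F)nc1N1CCC(C)(C)CC1)c1ccc(NS(C)(=O)=O)c(F)c1`: compound 3 gives 0.3 nM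

Compound 3 stands level with compound 2 at the digits given, and the two of them share the lowest number of the three; the gap that separates them from the third is a 47-fold lower number from compound 1 to compound 3 (1.67 log units; beyond the scatter).

Compound 4 `CC(C(=O)NCc1ccc(C(F)(F)F)nc1N1CCC(O)CC1)c1ccc(NS(C)(=O)=O)c(F)c1` is the next step from compound 3. The change is 4-hydroxypiperidin-1-yl in place of 4,4-dimethylpiperidin-1-yl on an aromatic carbon.

Two of the measured steps concern the group on this aromatic carbon. The step of a 47-fold lower number from compound 1 to compound 2 (1.67 log units; beyond the scatter) and the step of a 47-fold lower number from compound 1 to compound 3 (1.67 log units; beyond the scatter) both replace an arylamino group with a saturated ring and are large. The step that bears most directly on compound 4 is no change at the digits printed from compound 2 to compound 3 (within the scatter), where one saturated six-membered ring replaces another without any change in this assay. Among the measured compounds shown here, no measured step introduces a hydrogen-bond donor on this ring, so that part of the change is untested here. Compound 4 is therefore expected to stay close to compound 3, with a modest allowance for the new hydroxyl, as a 3.3-fold higher number from compound 3 to compound 4 (0.52 log units; beyond the scatter). The estimate for compound 4 in this assay is 1 nM, in the range 0.3 nM to 4 nM.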

Compound 4, inhibition constant: "not active" (no number reported)
Compound 4 has no reported number here; no gap can be computed for the estimate.
By their numbers in this assay, from the lowest: compounds 2 and 3 (each within the scatter of the next); then compound 1.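

Among the compounds shown here, compound 4 is recorded as not active in this assay and carries no number, so no step from compound 3 to compound 4 can be read. The compounds shown leave open how 4-hydroxypiperidin-1-yl compares in size of effect with 4,4-dimethylpiperidin-1-yl on this carbon. No evidence here bears on this result.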